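The compounds below may be only part of what the source reports. "The series", "measured", "known", "first", "only" and "open" are said of these compounds alone.

Compound 1 `C[C@H](/N=C(\S)Nc1ccccn1)c1cccc2ccccc12` and compound 2 `C[C@H](/N=C(\S)Nc1nc2ccccc2s1)c1cccc2ccccc12` share the same thiourea arm and differ in the ring on the other side; the difference between the two cores is not broken down here. In a functional assay on RBL-2H3 cells (Rattus norvegicus) for inhibition (a higher number here means a weaker inhibitor, a lower number a stronger inhibitor), compound 1 gives only a limit, > 100000 nM. In this assay compound 2 also gives only a limit, > 100000 nM. Compound 3 `Cc1cccc(N/C(S)=N/[C@@H](C)c2cccc3ccccc23)n1` carries methyl in place of hydrogen on an aromatic carbon and in this assay gives 1600 nM. For the measured compounds named here, the step of an at least 62-fold lower number from compound 1 to compound 3 (1.79 log units; beyond the scatter) is the single measured change in the set, and its size is bounded by the limit of > 100000 nM in this assay, at which 2 of the 3 values shown sit. Compound 4 `Cc1cccc2sc(N/C(S)=N/[C@@H](C)c3cccc4ccccc34)nc12` is not yet measured and carries methyl in place of hydrogen on an aromatic carbon. This is the same kind of change as in compound 3, but the place differs: there the methyl sits on a six-membered aromatic ring with one nitrogen, next to the ring nitrogen, meta to a large group; here on a six-membered aromatic ring of carbon only, part of a fused system of two rings, ortho to a fused ring, meta to a fused ring. For compound 4 a step of an at least 10-fold lower number from compound 2 to compound 4 (1.00 log units; beyond the scatter) in this assay is expected, resting on an at least 62-fold lower number from compound 1 to compound 3 (1.79 log units; beyond the scatter) and weakened by the different core. The estimate for compound 4 is 10000 nM, between 1500 nM and 100000 nM.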

Compound 4, half-maximal inhibitory concentration: > 100000 nM
Compound 4: only a limit was reported; the forecaster's own chance of this, stated with the estimate: 35%; middle value at least 10-fold (1.00 log units) away from the limit.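

In this assay, compound 2 and compound 4 each give only a limit, so no step between them can be read: the limit of > 100000 nM in this assay, at which 3 of the 4 values shown sit.

The compounds shown leave open whether methyl in place of hydrogen on the core of compound 2 changes inhibition at all, and whether the gain seen with compound 3 carries over to that core.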